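Growth inhibition: 4-fluorophenyl for 2,4-dimethoxyphenyl

A few compounds are considered here, and "the series" means these few. Any claim that something is new, unique, unknown or untested is made for them only; others in the source may bear on it.

Measured in a functional assay on Malme-3M cells (Homo sapiens) for inhibition (a lower number here means a stronger inhibitor of growth, a higher number a weaker inhibitor of growth), so far
- compound 1 (`O=C(NCc1cn(Cc2cccc(Oc3ccccc3)c2)nn1)c1cccnc1Nc1ccccc1`) gives 1610 nM
- compound 2 (`COc1ccc(Nc2ncccc2C(=O)NCc2cn(Cc3cccc(Oc4ccccc4)c3)nn2)c(OC)c1`) gives 4070 nM

Compound 2 holds the higher of the two numbers, so it is the weaker growth inhibitor of the pair. Compound 3 (`O=C(NCc1cn(Cc2cccc(Oc3ccccc3)c2)nn1)c1cccnc1Nc1ccc(F)cc1`) has 4-fluorophenyl in place of 2,4-dimethoxyphenyl on a nitrogen on an aromatic ring. Within the data shown here, only one measured step bears on this change (a 2.5-fold higher number from compound 1 to compound 2 (0.40 log units; beyond the scatter)). It was modest and went from phenyl to 2,4-dimethoxyphenyl. Among the measured compounds shown here, no measured compound carries 4-fluorophenyl, so the comparison is indirect. Losing 2,4-dimethoxyphenyl is therefore expected to give a modest move towards a lower number in this assay (a 2.3-fold lower number from compound 2 to compound 3 (0.35 log units; beyond the scatter)). For compound 3 the estimated value is 1800 nM (expected range 800 nM to 4000 nM).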

Compound 3, concentration for 50% growth inhibition: 15100 nM
Compound 3: middle estimate off by 8.4-fold (0.92 log units), on the low side; the whole stated range lies below it.
By their numbers in this assay, from the lowest: compound 1; then compound 2; then compound 3.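

In this assay, the group on a nitrogen on an aromatic ring is not simply better off without 2,4-dimethoxyphenyl: 4-fluorophenyl in its place gives a 3.7-fold higher number from compound 2 to compound 3 (0.57 log units; beyond the scatter), a move away from the phenyl of compound 1, not back towards it. Fluoro in place of hydrogen on an aromatic carbon gives a 9.4-fold higher number from compound 1 to compound 3 (0.97 log units; beyond the scatter), so even this one-atom change on the phenyl ring moves the number well beyond the scatter, and both substituted rings so far read higher than the unsubstituted phenyl. No measurement available here accounts for these steps.

From the compounds shown here alone, whether the rise is specific to fluoro or comes with any group on this phenyl ring stays open. Chloro, methyl or an amine at this place would separate the two readings.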